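Methyl on the aromatic nitrogen: a second instance

The compounds below may be only part of what the source reports. "The series", "measured", "known", "first", "only" and "open" are said of these compounds alone.

The measured compounds:
compound 1, `COc1ccc2c(c1)c(/C=N\NC(=O)c1cn(C)c3ccccc13)cn2Cc1ccc(Cl)cc1`, giving 21200 nM in a functional assay on PC-3 cells (Homo sapiens) for cytotoxicity; on this read-out higher numbers stand for weaker inhibition and lower numbers for stronger inhibition;
compound 2, `COc1ccc2c(c1)c(/C=N\NC(=O)c1c[nH]c3ccccc13)cn2Cc1ccc(Cl)cc1`, giving 30300 nM in this assay;
compound 3, `COc1ccc(Cn2cc(/C=N\NC(=O)c3c[nH]c4ccccc34)c3ccc(F)cc32)cc1`, giving 18400 nM in this assay.

Compound 1 and compound 2 share one core and differ in a single place: methyl in place of hydrogen on an aromatic nitrogen. This change produced a 1.4-fold lower number from compound 2 to compound 1 (0.16 log units; within the scatter), a step that stays inside the usual scatter of the read-out, so the two numbers cannot be told apart with confidence. Compound 3 is built on a different core; the difference between the two cores is not broken down here. Its number and the numbers of compound 1 and compound 2 all lie within the scatter of one another, so no order among the three can be claimed.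

Compound 4, `COc1ccc(Cn2cc(/C=N\NC(=O)c3cn(C)c4ccccc34)c3ccc(F)cc32)cc1`, has not been measured. It differs from compound 3 by methyl in place of hydrogen on an aromatic nitrogen, the same change that leads from compound 2 to compound 1 and at the same place. Going by the values given here, the only guide available is that earlier pair, where the change gave a 1.4-fold lower number from compound 2 to compound 1 (0.16 log units; within the scatter). On that basis the expected step is of about the same small size, a 1.2-fold lower number from compound 3 to compound 4 (0.09 log units; within the scatter), again within the scatter. In this assay compound 4 is therefore estimated to give 15000 nM, with an expected range from 6000 nM to 40000 nM.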

Compound 4, half-maximal inhibitory concentration: 12800 nM
Estimate against measurement, compound 4: 1.2-fold (0.07 log units) above; low and high end bracket the measured number.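

On the second core, methyl in place of hydrogen on the aromatic nitrogen gave a 1.4-fold lower number from compound 3 to compound 4 (0.16 log units; within the scatter) in this assay, so compound 3 and compound 4 cannot be told apart with confidence, just as the earlier pair could not. Set side by side, the two steps agree closely and no difference between the cores can be seen in how this change reads out: the same change on two cores in this assay, a 1.4-fold lower number (0.16 log units; within the scatter) from compound 2 to compound 1 and a 1.4-fold lower number (0.16 log units; within the scatter) from compound 3 to compound 4, 1.0-fold (0.00 log units) apart, within the scatter of two such steps. This shows that on these two cores the change leaves the read-out inside the usual scatter, but it does not show that the methyl group strengthens inhibition on either core, since neither step can be separated from the noise of repeated measurements, and two pairs say nothing about how the change would behave on any further core in the series.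

The compounds shown leave open whether any group on that aromatic nitrogen can shift the number beyond the scatter, for instance ethyl, a longer chain, or a chain ending in an amine or a carboxylic acid. They also leave open whether the same small replacement would read the same way in any assay other than this cytotoxicity measurement.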